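Trimethoxyphenyl cyclopropane amides: phenyl versus 4-methylbenzyl

This account rests on a few compounds, and the source may have more. Where it says the series, first, only, none or still open, it means among the compounds named here.

Measured compounds:
- compound 1, `CCOC(=O)[C@]1(C(=O)Nc2ccccc2)C[C@H]1c1cc(OC)c(OC)c(OC)c1`: 37300 nM
- compound 2, `CCOC(=O)C1(C(=O)NCc2ccc(C)cc2)CC1c1cc(OC)c(OC)c(OC)c1`: 18700 nM; 21400 nM (2 entries)

For the measured compounds named here, compound 1 is the only compound with a single number in a functional assay on A549 cells (Homo sapiens) for cytotoxicity, read by MTT assay, with a stated time of 48 h; on this read-out higher numbers stand for weaker inhibition and lower numbers for stronger inhibition; a further entry for it carries no single number. In this assay compound 1 gives 37300 nM, and compound 2 gives 18700 nM; 21400 nM (2 entries), whose repeated entries (the several entries of compound 2 in this assay, 18700 nM; 21400 nM (2 entries)) sit close together.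

Compound 3, `CCOC(=O)[C@]1(C(=O)NCc2ccc(C)cc2)C[C@H]1c1cc(OC)c(OC)c(OC)c1`, is not yet measured. It differs from compound 1 by 4-methylbenzyl in place of phenyl on an amide-type nitrogen. Going by the values given here, compound 2 carries the same 4-methylbenzyl group on its amide-type nitrogen but without a defined arrangement at the ring carbons, so its number gives the nearest point of reference, though no step between it and compound 3 has been counted.

Among the compounds with values here, no measured step covers this change. Going from compound 1 to compound 3, a modest move toward stronger inhibition is expected, a 1.9-fold lower number from compound 1 to compound 3 (0.27 log units; within the scatter), a size that lies at the edge of the usual scatter rather than clearly beyond it. Compound 3 is therefore estimated at 20000 nM, with a range from 10000 nM to 40000 nM.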

Compound 3, half-maximal inhibitory concentration: 13300 nM
Compound 3: middle estimate off by 1.5-fold (0.18 log units), on the high side, and the stated range covers the measured number.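

The change on the amide-type nitrogen now has a measured size in this assay, between two compounds drawn with the same defined arrangement at the ring carbons: a 2.8-fold lower number from compound 1 to compound 3 (0.45 log units; beyond the scatter), a modest step but one that clears the usual scatter. Compound 2, which carries the same 4-methylbenzyl group, gives 18700 nM; 21400 nM (2 entries) and compound 3 gives 13300 nM, and the repeated values show how closely this number holds for compound 2: the several entries of compound 2 in this assay, 18700 nM; 21400 nM (2 entries). These two compounds cannot settle what the defined arrangement itself contributes, because their comparison rests on a difference in how they are drawn: the fact that one of compounds 2 and 3 is drawn with a defined configuration and the other without, at the place where they differ.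

The step changes two things at once, the added carbon link to the ring and the methyl group on it, so a plain benzyl group on the same nitrogen would be needed to tell these two apart. Also open, on these data alone, is how a carboxylic acid in place of the ethyl ester, or a longer chain on the amide-type nitrogen, would behave on the shared core.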